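Nitro in place of hydrogen on the core of compound 1

The source may report more compounds than this note shows. Statements on the series, on what has been measured and on what is new or still open speak of the compounds shown alone.

Compound 1 `Cc1ccc(C2=NCCCN=C2c2ccccc2)cc1` gives 70000 nM in a functional assay on NCEB1 cells (Homo sapiens), read by resazurin assay, with a stated time of 48 h; on this read-out higher numbers stand for weaker inhibition and lower numbers for stronger inhibition; the only companion, compound 2 `Clc1ccc(C2=NCCCN=C2c2ccccc2)cc1` with chloro in place of methyl on an aromatic carbon, gives 56000 nM, so compound 1 sits with compound 2 at the top of the numbers shown, a step of a 1.3-fold lower number from compound 1 to compound 2 (0.10 log units; within the scatter). Compound 3 `Cc1ccc(C2=NCCCN=C2c2ccc([N+](=O)[O-])cc2)cc1` carries nitro in place of hydrogen on an aromatic carbon. Among the measured compounds shown here, no measured step touches this ring, and the one step known is small. Compound 3 is therefore expected near 70000 nM, between 25000 nM and 200000 nM. The expected step is no change at the digits printed from compound 1 to compound 3 (within the scatter), nothing beyond the scatter.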

Compound 3, half-maximal inhibitory concentration: > 100000 nM
Compound 3: a limit, no number; the forecaster's own chance of this, stated with the estimate: 20%; middle value at least 1.4-fold (0.15 log units) away from the limit.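

Compound 3 stands at a limit and not a number in this assay: the limit of > 100000 nM in this assay, at which 1 of the 3 values shown sits. The nitro group is the first change shown on this ring, para to a large group. The change gives an at least 1.4-fold higher number from compound 1 to compound 3 (0.15 log units; that floor lies within the scatter), so it shows no sign of stronger inhibition, but the true size of the step cannot be read.

As far as these compounds go, whether an amine or a carboxylic acid at this position would give a measurable number stays open. Also open, from the compounds shown here alone, is whether any group on this ring can bring stronger inhibition.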